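Replacing Fluoro with Hydroxymethyl on the Fused Ring

A few compounds are considered here, and "the series" means these few. Any claim that something is new, unique, unknown or untested is made for them only; others in the source may bear on it.

Compound 1, `O=C(O)CCc1ccc(OCC2COc3cc(Br)ccc3O2)cc1F`, gives 980 nM in a functional assay on HEK293 cells for agonist activity at Free fatty acid receptor 1 (Homo sapiens), read by fluorescence and calcium flux, with a stated time of 10 min; a higher number here means that more compound is needed for the effect, a lower number that less compound is needed.
Compound 2, `CC#C[C@@H](CC(=O)O)c1ccc(OC[C@H]2COc3cc(Cl)ccc3O2)cc1`, gives 110 nM in this assay.
Compound 3, `CC#C[C@@H](CC(=O)O)c1ccc(OC[C@H]2COc3ccc(F)cc3O2)cc1`, gives 210 nM in this assay.

Among the three measured values, compound 3 stands second highest. Its nearest neighbour is compound 2, whose number lies within the usual scatter of compound 3, so the two cannot be told apart. The furthest is compound 1, whose gap to compound 3 lies beyond the scatter: compound 1 needs more compound for the same effect.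

Compound 4, `CC#C[C@@H](CC(=O)O)c1ccc(OC[C@H]2COc3ccc(CO)cc3O2)cc1`, has not yet been measured. It differs from compound 3 in one place: hydroxymethyl in place of fluoro on an aromatic carbon. Among the measured compounds shown here, a hydroxymethyl in place of a fluoro on the fused ring is a change for which no comparable pair has been measured here, so the expectation rests on the measured values alone. The three measured compounds span a modest range in this assay, and a step of similar or smaller size is expected, most likely toward a somewhat higher number or none beyond the scatter. Compound 4 is therefore expected to give about 350 nM, within a range from 120 nM to 1000 nM. This estimate corresponds to an expected step of a 1.7-fold higher number from compound 3 to compound 4 (0.22 log units; within the scatter).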

Compound 4, half-maximal effective concentration: > 30000 nM
Compound 4 was reported as a limit; the forecaster's own chance of this, stated with the estimate: 5%; middle value at least 85-fold (1.93 log units) from the limit.
By their numbers in this assay, from the lowest: compounds 2 and 3 (each within the scatter of the next); then compound 1. At a limit, above all of these: compound 4.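

On the aromatic carbon that is meta to a fused ring and para to a fused ring, the choice of group proves decisive: in this assay, hydroxymethyl in place of fluoro gives an at least 140-fold higher number from compound 3 to compound 4 (2.15 log units; beyond the scatter). The earlier compounds shown here offered no step between compounds differing in one place, and their numbers gave no sign that a single change here could carry so much weight. On these data alone, compound 4 stands only as a limit of the assay, so the true size of the step stays unknown: the limit of > 30000 nM in this assay, at which 1 of the 4 values shown sits.

The compounds shown leave open whether the oxygen of the hydroxymethyl or the added carbon matters more, a question that a methyl or a methoxy on this carbon would address. They also leave open whether a longer chain or a carboxylic acid here would fare the same way.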